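The source may report more compounds than this note shows. Statements on the series, on what has been measured and on what is new or still open speak of the compounds shown alone.

Measured compounds and their values:

Compound 1, `CCSCCc1c[nH]c2ccc(F)cc12`: in an assay on isolated protein (urine) for inhibition of Myeloperoxidase (Homo sapiens), with a stated time of 5 min (a higher number here means a weaker inhibitor, a lower number a stronger inhibitor), compound 1 gives > 100 nM, a limit of the assay rather than a number.
Compound 2, `CCCc1c[nH]c2ccc(F)cc12`: compound 2 gives > 100 nM, again a limit and not a number.
Compound 3, `N#CCCCc1c[nH]c2ccc(F)cc12`: compound 3 gives 63 nM.

Compound 3 thus holds the only number shown; the two other values sit at the limit (the limit of > 100 nM in this assay, at which 2 of the 3 values shown sit). The steps into compound 3 are floors only: an at least 1.5-fold lower number from compound 1 to compound 3 (0.20 log units; that floor lies within the scatter) and an at least 1.5-fold lower number from compound 2 to compound 3 (0.20 log units; that floor lies within the scatter), each a floor that lies within the scatter. The step that the two limits leave unreadable from compound 1 to compound 2 cannot be read from two limits.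

Compound 4, `NC(=O)CCCc1c[nH]c2ccc(F)cc12`, differs from compound 3 by carbamoyl in place of cyano on a saturated chain carbon, three bonds along the chain from an aromatic carbon. For the measured compounds named here, no measured step changes the cyano group itself; the two steps reaching compound 3 introduce it, and both read only as floors. Nothing in the series therefore points to a step beyond the scatter in either direction. For compound 4 the expected value is 70 nM, with a range of 25 nM to 200 nM, an estimated step of a 1.1-fold higher number from compound 3 to compound 4 (0.05 log units; within the scatter) from compound 3.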

Compound 4, half-maximal inhibitory concentration: 18 nM
Beside the measured number, compound 4's estimate is 3.9-fold (0.59 log units) above it; measured number outside the range, below it.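

In this assay, for the compounds shown here, the group on this saturated chain carbon, three bonds along the chain from an aromatic carbon, now gives the first readable step beyond the scatter (an exact one: a 3.5-fold lower number from compound 3 to compound 4 (0.54 log units; beyond the scatter)), so carbamoyl and cyano are not interchangeable at this place. Carbamoyl in place of hydrogen also reads beyond the scatter (an at least 5.5-fold lower number from compound 2 to compound 4 (0.74 log units; beyond the scatter)), as does carbamoylmethyl in place of ethylsulfanyl (an at least 5.5-fold lower number from compound 1 to compound 4 (0.74 log units; beyond the scatter)). These two steps are floors only, because compound 1 and compound 2 each sit at a limit and give no number: the limit of > 100 nM in this assay, at which 2 of the 4 values shown sit.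

Open, from the compounds shown here alone, is whether the step belongs to the carbamoyl group itself or also appears with a carboxylic acid or a methyl ester at this place. Also open, going by these compounds, is how a shorter or longer chain carrying the carbamoyl would read.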